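The source may report more compounds than this note shows. Statements on the series, on what has been measured and on what is new or still open speak of the compounds shown alone.

Of the compounds shown here, three have been measured in an ADME assay on HeLa cells (Homo sapiens) for cytotoxicity, read by microscopy, with a stated time of 6 days (a higher number here means that more compound is tolerated, a lower number that less compound is tolerated), and none has yet given a number. Compound 1 `CCCCCCNc1cnc(C(=O)NCc2ccccc2)cn1` reports only the limit of the assay, > 100000 nM. Compound 2 `CCCCCCNc1cncc(C(=O)NCc2ccccc2)n1` likewise reports only a limit, > 100000 nM. Compound 3 `CCCCNc1nccnc1C(=O)NCc1ccccc1` gives > 100000 nM, which is again a limit and not a measured number. For the measured compounds named here, all three values therefore sit at the limit of > 100000 nM in this assay, at which 3 of the 3 values shown sit, so no step between measured compounds can be sized, and compound 3 stands where every other compound stands. Compound 4 `CCCCCNc1nccnc1C(=O)NCc1ccccc1` remains to be measured. It differs from compound 3 by methyl in place of hydrogen on a saturated chain carbon, four bonds along the chain from a nitrogen on an aromatic ring. Going by the values given here, no measured step informs this change; in this assay a step of no size beyond the scatter is expected, and the estimated step of a number no higher from compound 3 to compound 4 (the limit leaves the size open) would leave the value at the limit. Compound 4 is expected at about 100000 nM, within 50000 nM to 200000 nM.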

Compound 4, minimum cytotoxic concentration: > 100000 nM
Compound 4 gave a limit, no number; the forecaster's own chance of this, stated with the estimate: 85%; the middle value lies on the limit itself.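

For the compounds shown here, compound 3 and compound 4 each give only a limit, so no step between them can be read. The compounds shown leave open at what concentration any of them would give a number in this assay.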